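Swapping the Aromatic Group on a Hydrazone-Linked Nucleoside

This account rests on a few compounds, and the source may have more. Where it says the series, first, only, none or still open, it means among the compounds named here.

Three compounds share one core and differ only in the aromatic group joined to the carbon with a double bond to nitrogen. In an assay on CHO-K1 cells for displacement of a labelled ligand from adenosine receptor A1 (Homo sapiens), read by scintillation counting, with a stated time of 60 min (on this read-out lower numbers stand for stronger inhibition and higher numbers for weaker inhibition), compound 1 `N#Cc1ccc(/C=N/Nc2nc(N)c3ncn([C@@H]4O[C@H](CO)[C@@H](O)[C@H]4O)c3n2)cc1` gives 4.1 nM. Compound 2 `Nc1nc(N/N=C/c2cccc(OCc3ccccc3)c2)nc2c1ncn2[C@@H]1O[C@H](CO)[C@@H](O)[C@H]1O` gives 13 nM, and compound 3 `Nc1nc(N/N=C/c2ccc3ncccc3c2)nc2c1ncn2[C@@H]1O[C@H](CO)[C@@H](O)[C@H]1O` gives 9.8 nM. Compound 3 thus shows the second-highest of the three numbers: compound 2 lies within the scatter of it, while the step of a 2.4-fold higher number from compound 1 to compound 3 (0.38 log units; beyond the scatter) is the only one beyond the scatter. Compound 4 `Nc1nc(N/N=C/c2ccc(-n3ccnc3)cc2)nc2c1ncn2[C@@H]1O[C@H](CO)[C@@H](O)[C@H]1O` carries 4-(1H-imidazol-1-yl)phenyl in place of quinolin-6-yl on a carbon with a double bond to nitrogen. Within the data shown here, that single step is the only one bearing on the change, and it was modest; like compound 1, compound 4 bears a substituted phenyl, so a small move toward lower numbers, if any, is expected. Compound 4 is estimated at 8 nM, between 3 nM and 25 nM. The expected step is a 1.2-fold lower number from compound 3 to compound 4 (0.09 log units; within the scatter).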

Compound 4, inhibition constant: > 10000 nM
Compound 4: no number, only a limit; the forecaster's own chance of this, stated with the estimate: 2%; middle value at least 1200-fold (3.09 log units) from the limit.
By their numbers in this assay, from the lowest: compound 1; then compounds 3 and 2 (each within the scatter of the next). At a limit, above all of these: compound 4.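

The earlier changes at this carbon with a double bond to nitrogen were modest, so the aromatic group there seemed open to exchange, yet 4-(1H-imidazol-1-yl)phenyl brings an at least 1000-fold higher number from compound 3 to compound 4 (3.00 log units; beyond the scatter). On the phenyl ring, 1H-imidazol-1-yl in place of cyano on an aromatic carbon likewise brings an at least 2400-fold higher number from compound 1 to compound 4 (3.38 log units; beyond the scatter). Compound 4 has only a limit, not a number: the limit of > 10000 nM in this assay, at which 1 of the 4 values shown sits.

The compounds shown leave open whether this sharp loss is specific to 1H-imidazol-1-yl, or whether a pyrrole ring, an amine or a carboxylic acid in place of cyano would behave the same way.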